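The source may hold more compounds than are shown below. What is called first, only, known or untested is meant among the compounds shown, and "the series" means these compounds.

Compound 1 (`Cn1c(=O)c(S(=O)(=O)c2ccc(OC(=O)CCCCC3SCC4NC(=O)NC43)cc2)cc2cnc(Nc3ccc4[nH]ccc4c3)nc21`) gives 500 nM
Compound 2 (`Cn1c(=O)c(S(=O)(=O)c2ccc(F)cc2)cc2cnc(Nc3ccc4[nH]ccc4c3)nc21`) gives 200 nM

Going by the values given here, both numbers come from a functional assay on COLO 205 cells (Homo sapiens) for inhibition, read by trypan blue exclusion, with a stated time of 72 h (on this read-out higher numbers stand for weaker inhibition of growth and lower numbers for stronger inhibition of growth), and the two compounds do not differ in one place alone, so no single-change step has been measured yet. Compound 2 has the lower of the two numbers, and its gap to compound 1 lies beyond the scatter.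

Compound 3 (`Cn1c(=O)c(S(=O)(=O)c2ccc(O)cc2)cc2cnc(Nc3ccc4[nH]ccc4c3)nc21`) has not yet been measured. It differs from compound 2 by hydroxy in place of fluoro on an aromatic carbon and so turns 4-fluorophenyl into 4-hydroxyphenyl, with the change on an aromatic carbon para to a large group.

The only spread available runs from compound 2 at 200 nM to compound 1 at 500 nM and is modest. A small move toward a higher number in this assay, meaning slightly weaker inhibition of growth, is therefore expected. The expected move is a 1.5-fold higher number from compound 2 to compound 3 (0.18 log units; within the scatter) and is not expected to clear the scatter. Compound 3 is estimated at 300 nM with an expected range from 100 nM to 900 nM in this assay.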

Compound 3, concentration for 50% growth inhibition: 250 nM
Compound 3: middle estimate off by 1.2-fold (0.08 log units), on the high side; the range from low to high includes it.
By their numbers in this assay, from the lowest: compounds 2, 3 and 1 (each within the scatter of the next, the first and the last beyond it).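

In this assay, going by these compounds alone, hydroxy in place of fluoro on an aromatic carbon para to a large group gives a 1.3-fold higher number from compound 2 to compound 3 (0.10 log units; within the scatter), the first single-change step. This carbon therefore accepts the move from 4-fluorophenyl to 4-hydroxyphenyl, which brings in a hydrogen-bond donor and a hydrogen-bond acceptor, with no change in growth inhibition that can be told from the scatter of this read-out. Nothing measured on these compounds accounts for this outcome, and the step alone gives no explanation for it.

Still open, from the compounds shown here alone, is whether an amine, a carboxylic acid, a methoxy group or a longer chain on this same aromatic carbon would also stay within the scatter of compound 2, or would instead move the number clearly in either direction in this assay. With one step at one position, it is also unknown whether hydroxy in place of fluoro would give a similar result elsewhere on the shared core.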